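Exchanging the aryl group on the aromatic nitrogen

The source may hold more compounds than are shown below. What is called first, only, known or untested is meant among the compounds shown, and "the series" means these compounds.

Measured compounds:
compound 1, `Cc1ccc(-n2nc(-c3ccc(C(F)(F)F)cc3O)nc2-c2ccccc2O)cc1`, gives 94.1% in a functional assay on PC-12 cells (Rattus norvegicus) for cytotoxicity, read by MTT assay, with stated times of 2 h and 24 h, tested at 5 uM; a lower number here means a weaker effect, a higher number a stronger effect of the compound at the concentration tested
compound 2, `CC(C)(C)c1ccc(-n2nc(-c3ccc(C(F)(F)F)cc3O)nc2-c2ccccc2O)cc1`, gives 77.8% in this assay
compound 3, `Oc1cc(C(F)(F)F)ccc1-c1nc(-c2ccccc2O)n(-c2ccccc2C(F)(F)F)n1`, gives 80% in this assay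

Compound 3 stands second highest of the three numbers: a number 2.2 percentage points higher from compound 2 to compound 3 (within the scatter), whereas a number 14.1 percentage points lower from compound 1 to compound 3 (beyond the scatter). Compound 4, `Oc1cc(C(F)(F)F)ccc1-c1nc(-c2ccccc2O)n(-c2cccc(Cl)c2)n1`, differs from compound 3 in one place: 3-chlorophenyl in place of 2-(trifluoromethyl)phenyl on an aromatic nitrogen. Within the data shown here, the steps that bear on this change are those that also exchange the group on the aromatic nitrogen, namely a number 14.1 percentage points lower from compound 1 to compound 3 (beyond the scatter) and a number 2.2 percentage points higher from compound 2 to compound 3 (within the scatter); the third step, a number 16.3 percentage points lower from compound 1 to compound 2 (beyond the scatter), shows the same modest spread. Among the measured compounds shown here, no measured step covers 3-chlorophenyl itself. Compound 4 is therefore expected to show a number 3 percentage points higher from compound 3 to compound 4 (within the scatter), no step beyond the scatter, because a number 2.2 percentage points higher from compound 2 to compound 3 (within the scatter). Compound 4 is estimated at 83%, with a range from 70% to 95%.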

Compound 4, a percentage reported as activity, at one concentration (the size of the read-out at that concentration, not a potency): 92.7%
Compound 4: middle estimate off by 9.7 percentage points, on the low side; the measured number falls inside the stated range.
By their numbers in this assay, from the lowest: compounds 2 and 3 (each within the scatter of the next); then compounds 4 and 1 (each within the scatter of the next).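

The aryl group on the aromatic nitrogen can also raise the read-out in this assay: 3-chlorophenyl in place of 2-(trifluoromethyl)phenyl gives a number 12.7 percentage points higher from compound 3 to compound 4 (beyond the scatter), and in place of 4-(tert-butyl)phenyl it gives a number 14.9 percentage points higher from compound 2 to compound 4 (beyond the scatter). Against 4-methylphenyl it gives a number 1.4 percentage points lower from compound 1 to compound 4 (within the scatter), so two different aryl groups share the top of the series. Nothing available explains these steps. The compounds shown leave open whether an aryl group bearing an amine, or a longer alkyl chain in place of the aryl group on this nitrogen, would hold this level.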